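This account rests on a few compounds, and the source may have more. Where it says the series, first, only, none or still open, it means among the compounds named here.

Compound 1 `CC1CC/C(=N\Nc2cccc(Br)c2)c2ncc(C(=O)O)c(=O)n21` and compound 2 `CCOc1cccc(N/N=C2\CCC(C)n3c2ncc(C(=O)O)c3=O)c1` share one core and differ only in the group on the aromatic ring attached through the hydrazone nitrogen. In a functional assay on the whole organism for inhibition, with Rattus norvegicus as the target (a higher number here means that more compound is needed for the effect, a lower number that less compound is needed), compound 1 gives 0.4 umol/kg, and compound 2 gives 0.2 umol/kg. Of these two numbers compound 1 holds the higher one, but the step of a 2.0-fold lower number from compound 1 to compound 2 (0.30 log units; within the scatter) lies within the scatter, so the two compounds cannot be told apart on this evidence.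

Compound 3 `Cc1ccc(N/N=C2\CCC(C)n3c2ncc(C(=O)O)c3=O)cc1` is not yet measured in this assay. Its change from compound 1 is 4-methylphenyl in place of 3-bromophenyl on an amine nitrogen. Within the data shown here, the only measured step, from compound 1 to compound 2, also swaps the substituent on that aromatic ring, and it stayed within the scatter; no measured pair shows bromo against methyl or a change of the substituent's position. With that single, small precedent, the expected step of no change at the digits printed from compound 1 to compound 3 (within the scatter) is estimated to stay within the scatter, in no clear direction. The estimate for compound 3 in this assay is therefore 0.4 umol/kg, with a range from 0.15 umol/kg to 1.1 umol/kg.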

Compound 3, dose for 50% inhibition: 1.3 umol/kg
Estimate against measurement, compound 3: 3.3-fold (0.51 log units) below; measured number above the stated range.
By their numbers in this assay, from the lowest: compounds 2 and 1 (each within the scatter of the next); then compound 3.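

In this assay, among these compounds, changing the group on the amine nitrogen from 3-bromophenyl to 4-methylphenyl gives a 3.3-fold higher number from compound 1 to compound 3 (0.51 log units; beyond the scatter), the first step to pass beyond the scatter, although it is modest in size. The earlier swap of bromo for ethoxy had left the number within the scatter, which could have suggested that this aromatic ring accepts any change, but the new step shows that at least one change here means more compound is needed for the effect. Nothing available explains why this happens.

This one step replaces bromo with methyl and also differs in the number that gives the substituent's place in the group's name, so the compounds shown cannot say which of the two differences accounts for the higher number; that would take a pair differing in only one of them. From the compounds shown here alone, it also remains open how this ring would respond to quite different substituents, such as an amine, a carboxylic acid or a longer chain like butyl.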